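The source may hold more compounds than are shown below. What is called first, only, known or untested is meant among the compounds shown, and "the series" means these compounds.

Working notes on the series. Two analogues sharing one core have been measured in a functional assay on CHO cells for antagonist activity at Orexin receptor type 2 (Homo sapiens), read by FLIPR and calcium flux; a higher number here means a weaker inhibitor, a lower number a stronger inhibitor. Compound 1 `C=Cc1nc(CC)n2c1C(CCc1ccc(C(F)(F)F)cc1)N([C@@H](C(=O)NC)c1ccccc1)CC2` gives 23 nM in this assay. Compound 2 `CCc1nc(SC)c2n1CCN([C@@H](C(=O)NC)c1ccccc1)[C@H]2CCc1ccc(C(F)(F)F)cc1` gives 14 nM in this assay. Compound 1 carries the highest of the two numbers, but the gap between compound 1 and compound 2 lies within the scatter of repeated measurements, so no order can be read from these two values.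

The next step goes from compound 1 to compound 3 `CCc1nc(C)c2n1CCN([C@@H](C(=O)NC)c1ccccc1)C2CCc1ccc(C(F)(F)F)cc1`, which differs from compound 1 by methyl in place of vinyl on an aromatic carbon. Going by the values given here, no measured pair isolates such an exchange, so the expectation rests on the two values above alone. Compound 2 carries a different small group at the same aromatic carbon and its value in this assay sits near that of compound 1, which gives no sign that this position moves the number much. The step of a 1.2-fold lower number from compound 1 to compound 3 (0.06 log units; within the scatter) is therefore expected to be small, without a clear direction, likely no change beyond the scatter. Compound 3 is estimated at 20 nM in this assay, with a range from 7 nM to 60 nM.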

Compound 3, half-maximal inhibitory concentration: 24 nM
Estimate against measurement, compound 3: 1.2-fold (0.08 log units) below, and the stated range covers the measured number.
By their numbers in this assay, from the lowest: compounds 2, 1 and 3 (each within the scatter of the next).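

Methyl in place of vinyl on this aromatic carbon is now read directly, with a 1.0-fold higher number from compound 1 to compound 3 (0.02 log units; within the scatter) in this assay. The earlier compounds shown here offered only an indirect hint about this position, whereas this pair shows that the loss of the double bond outside aromatic rings, with one heavy atom fewer, leaves the number within the scatter. No measurement at hand bears on why the two groups read alike.

Vinyl and methyl both enter as carbon groups with no hydrogen-bond donors or acceptors and no net charge, so the compounds shown leave open how this carbon responds to a different kind of group. An amine, a carboxylic acid or a longer chain on this aromatic carbon, each compared directly with compound 1, would show whether the position stays this flat.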